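A few compounds are considered here, and "the series" means these few. Any claim that something is new, unique, unknown or untested is made for them only; others in the source may bear on it.

Measured compounds: compound 1 `O=C(CSC(=S)N[C@H]1CCOC1=O)Nc1ccc(F)cc1` with 5830 nM and compound 2 `CCOC(=O)c1ccc(NC(=O)CSC(=S)N[C@H]2CCOC2=O)cc1` with 60300 nM, both in a functional assay on MCF7 cells (Homo sapiens) for cytotoxicity, read by MTT assay, with a stated time of 72 h; on this read-out higher numbers stand for weaker inhibition and lower numbers for stronger inhibition.

Compound 2 holds the highest number of the two; its nearest neighbour is compound 1, which differs only at one aromatic carbon, and the step of a 10-fold higher number from compound 1 to compound 2 (1.01 log units; beyond the scatter) shows how much a single change at that position can move this assay. Compound 3 `O=C(CSC(=S)N[C@H]1CCOC1=O)Nc1ccc(C(=O)/C=C/c2ccc([N+](=O)[O-])cc2)cc1` is not yet measured. It differs from compound 2 by 2-(4-nitrophenyl)ethenyl in place of ethoxy on a carbonyl carbon. Among the measured compounds shown here, no measured step covers this kind of change; the only step at hand, the one from compound 1 to compound 2, concerns a different group at the same aromatic carbon and only shows that changes there can be large. Compound 3 is therefore expected to move in this assay by roughly a 6.7-fold lower number from compound 2 to compound 3 (0.83 log units; beyond the scatter), with wide uncertainty. The estimate for compound 3 in this assay is 9000 nM, between 1500 nM and 45000 nM.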

Compound 3, half-maximal inhibitory concentration: 2670 nM
The estimate for compound 3 lay 3.4-fold (0.53 log units) above the measured number, within the range that was stated.
By their numbers in this assay, from the lowest: compound 3; then compound 1; then compound 2.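

In this assay, the earlier step, a 10-fold higher number from compound 1 to compound 2 (1.01 log units; beyond the scatter), showed only a rise in the number from a change at the aromatic carbon. Keeping the carbonyl carbon and replacing ethoxy with 2-(4-nitrophenyl)ethenyl gives a 23-fold lower number from compound 2 to compound 3 (1.35 log units; beyond the scatter), so the ethoxycarbonyl group of compound 2 can be altered at this carbonyl carbon with a large move in the opposite direction. Nothing measured here accounts for this move, which brings in one six-membered aromatic ring and two double bonds outside aromatic rings in a single change.

The compounds shown leave open which part of the entering group matters, since the ring, the double bonds and the nitro group all arrive together. Going by these compounds, it also remains open how an amine in place of the nitro group, or a plain phenyl ring on the ethenyl chain, would read in this assay.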